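Aryl Amide Variation in a Benzamide Growth-Inhibitor Series

The source may hold more compounds than are shown below. What is called first, only, known or untested is meant among the compounds shown, and "the series" means these compounds.

Measured so far:
- compound 1, `COc1ccc(NC(=O)CNCCCC(=O)Nc2ccccc2N)cc1`: 8600 nM
- compound 2, `Nc1ccccc1NC(=O)c1ccc(NCC(=O)Nc2ccc(Cl)cc2)cc1`: 4200 nM
- compound 3, `Cc1ccc(NC(=O)CNc2ccc(C(=O)Nc3ccccc3N)cc2)cc1`: 12600 nM

In a functional assay on HCT-116 cells (Homo sapiens) for inhibition, read by MTT assay, with a stated time of 2 days (on this read-out higher numbers stand for weaker inhibition of growth and lower numbers for stronger inhibition of growth), compound 1 gives 8600 nM, the second highest of the three numbers. Compound 3 sits nearest, a gap within the scatter, so nothing separates the two; compound 2, with 4200 nM, stands lowest, a gap beyond the scatter from compound 1.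

Compound 4, `Nc1ccccc1NC(=O)CCCNCC(=O)Nc1ccccc1Cl`, differs from compound 1 in one place: 2-chlorophenyl in place of 4-methoxyphenyl on an amide-type nitrogen

Among the compounds with values here, only one measured step touches an aryl substituent: a 3.0-fold higher number from compound 2 to compound 3 (0.48 log units; beyond the scatter), a modest shift beyond the scatter, which in the reverse direction means that chloro in place of methyl lowered the number. Compound 4 carries a chloro where compound 1 carries a methoxy, on a different ring position and with methoxy rather than methyl as the starting group, so the step is at best a loose guide. A modest decrease in the number is therefore expected, a 1.7-fold lower number from compound 1 to compound 4 (0.24 log units; within the scatter), with a wide range. For compound 4 in this assay a value of 5000 nM is estimated, expected to lie between 2000 nM and 15000 nM.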

Compound 4, concentration for 50% growth inhibition: 21800 nM
The estimate for compound 4 lay 4.4-fold (0.64 log units) below the measured number; the whole stated range lies below it.
By their numbers in this assay, from the lowest: compound 2; then compounds 1, 3 and 4 (each within the scatter of the next, the first and the last beyond it).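

In this assay, 2-chlorophenyl in place of 4-methoxyphenyl on an amide-type nitrogen gives a 2.5-fold higher number from compound 1 to compound 4 (0.40 log units; beyond the scatter), so the aryl group on this nitrogen affects the number in the core of compound 1. In the other core, a 3.0-fold higher number from compound 2 to compound 3 (0.48 log units; beyond the scatter) places the chloro-bearing compound at the lower number, whereas here the chloro-bearing compound 4 has the higher number, so a chloro group does not go with a lower number in both cores. No measurement available here accounts for this rise.

The step changes both the substituent and its ring position, leaving open whether the rise follows the chloro group, its position or the loss of methoxy. A 2-methoxyphenyl or an unsubstituted phenyl on the same nitrogen would help to separate these readings.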